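A few compounds are considered here, and "the series" means these few. Any claim that something is new, unique, unknown or untested is made for them only; others in the source may bear on it.

Working notes on the series. Three compounds share one core and have been run in a functional assay on ECa-109 cells for antiproliferative activity against ECa-109 cell line (Homo sapiens), read by MTT assay, with a stated time of 48 h; on this read-out lower numbers stand for stronger inhibition and higher numbers for weaker inhibition. Compound 1 `c1ccc(Cn2cc(Cc3nnc(-c4ccccc4)c(-c4ccccc4)n3)nn2)cc1` gives 11100 nM. Compound 2 `Fc1ccc(Cn2cc(CSc3nnc(-c4ccccc4)c(-c4ccccc4)n3)nn2)cc1` gives 19100 nM. Compound 3 `COc1ccc(Cn2cc(CSc3nnc(-c4ccccc4)c(-c4ccccc4)n3)nn2)cc1` gives 28400 nM. Compound 2 stands second highest of the three numbers; its nearest neighbour is compound 3 and its furthest is compound 1, and both gaps are within the scatter, so no order among the three can be read from these numbers.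

Going by the values given here, the only single-point step measured so far is a 1.5-fold higher number from compound 2 to compound 3 (0.17 log units; within the scatter), a swap of one aromatic substituent on the benzyl group that left the read-out unchanged beyond the scatter.

Compound 4 `NS(=O)(=O)c1ccc(-n2cc(CSc3nnc(-c4ccccc4)c(-c4ccccc4)n3)nn2)cc1` is not yet measured. Against compound 2 the change is 4-sulfamoylphenyl in place of 4-fluorobenzyl on an aromatic nitrogen. Among the compounds with values here, this is a larger change than the one from compound 2 to compound 3: the methylene between the ring and the aromatic nitrogen is gone and a sulfamoyl group with one hydrogen-bond donor and two acceptors appears. Within the data shown here, no measured step covers either of these alterations, so the expectation rests on compound 2 alone. The step from compound 2 to compound 4 is expected to be a 1.0-fold higher number from compound 2 to compound 4 (0.02 log units; within the scatter), that is, no change beyond the scatter, with wide uncertainty. Compound 4 is therefore estimated at 20000 nM, in a range from 7000 nM to 60000 nM.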

Compound 4, half-maximal inhibitory concentration: > 100000 nM
Compound 4 gave a limit, no number; the forecaster's own chance of this, stated with the estimate: 15%; middle value at least 5.0-fold (0.69 log units) away from the limit.
By their numbers in this assay, from the lowest: compounds 1, 2 and 3 (each within the scatter of the next, the first and the last beyond it). At a limit, above all of these: compound 4.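

In this assay compound 4 carries a limit of the assay and not a number: the limit of > 100000 nM in this assay, at which 1 of the 4 values shown sits.

This position on the aromatic nitrogen does respond to change: 4-sulfamoylphenyl in place of 4-fluorobenzyl gives an at least 5.2-fold higher number from compound 2 to compound 4 (0.71 log units; beyond the scatter), and 4-sulfamoylphenyl in place of 4-methoxybenzyl gives an at least 3.5-fold higher number from compound 3 to compound 4 (0.54 log units; beyond the scatter). The earlier swap on the benzyl ring gave only a 1.5-fold higher number from compound 2 to compound 3 (0.17 log units; within the scatter), whereas these two steps lie beyond the scatter and, with a limit at one end, give only the smallest size the change can have.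

The compounds shown do not separate the loss of the methylene from the arrival of the sulfamoyl group, as both alterations come together in compound 4. A plain phenyl or a 4-sulfamoylbenzyl group on the same nitrogen would pull these two apart, and a carboxylic acid or an amine in place of the sulfamoyl group would show whether the result is tied to the sulfamoyl group itself.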